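The source may hold more compounds than are shown below. What is called first, only, known or untested is meant among the compounds shown, and "the series" means these compounds.

Among the measured compounds shown here, compound 2 `Cc1n[nH]c2nc(-c3ccc(NS(=O)(=O)c4cc(Cl)ccc4F)cc3)nc(OCC3(CN)COC3)c12` stands lowest of the two numbers so far in an assay for inhibition of serine/threonine-protein kinase Sgk1 (Homo sapiens), with stated times of 30 min and 60 min, in the presence of a further agent that is not named here; on this read-out higher numbers stand for weaker inhibition and lower numbers for stronger inhibition: compound 2 gives 1 nM, while compound 1 `Cc1n[nH]c2nc(-c3ccc(NS(=O)(=O)c4cc(Cl)ccc4F)cc3)nc(OCCC(=O)N(C)C)c12` gives 15 nM. For the measured compounds named here, the only measured step at this position, a 15-fold lower number from compound 1 to compound 2 (1.18 log units; beyond the scatter), shows the oxygen-borne substituent matters. Compound 3 `Cc1n[nH]c2nc(-c3ccc(NS(=O)(=O)c4cc(Cl)ccc4F)cc3)nc(OC3CCOCC3)c12` carries oxan-4-yl in place of (3-(aminomethyl)oxetan-3-yl)methyl on an oxygen on an aromatic ring. Going by the values given here, no measured pair exchanges this chain for a ring, so the direction rests on that single step; the number for compound 3 is expected to move back toward compound 1. Compound 3 is therefore estimated at 8 nM, within 2 nM to 40 nM. The expected step is an 8.0-fold higher number from compound 2 to compound 3 (0.90 log units; beyond the scatter).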

Compound 3, half-maximal inhibitory concentration: 5 nM
Compound 3: middle estimate off by 1.6-fold (0.20 log units), on the high side; measured number inside the range.
By their numbers in this assay, from the lowest: compound 2; then compound 3; then compound 1.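

The series now holds a ring set directly on the oxygen: oxan-4-yl, with no hydrogen-bond donor, still improves on the 2-(dimethylcarbamoyl)ethyl chain, with a 3.0-fold lower number from compound 1 to compound 3 (0.48 log units; beyond the scatter). The (3-(aminomethyl)oxetan-3-yl)methyl group nevertheless keeps the lowest number, with a 5.0-fold higher number from compound 2 to compound 3 (0.70 log units; beyond the scatter), so a low number at this position does not depend on that group alone, though it is best served by it so far. Nothing available explains either step.

Going by these compounds, whether the advantage of compound 2 rests on its amine or on its oxetane remains open. A piperidin-4-yl ring on the same oxygen, or a hydroxymethyl in place of the aminomethyl, would separate the two.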